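Solubility notes on the oxazolidinone series: compound 3 to 4

This account rests on a few compounds, and the source may have more. Where it says the series, first, only, none or still open, it means among the compounds named here.

Three compounds share a core and differ only in the group on a saturated chain carbon bound to a saturated ring carbon. In a physicochemical assay for solubility, read by HPLC, with a stated time of 24 h (on this read-out lower numbers stand for lower solubility and higher numbers for higher solubility), compound 1 `COC(=O)CC1CCN(C[C@H]2CN(c3ccc(-n4cc(-c5ccccn5)cn4)c(F)c3)C(=O)O2)CC1` gives 92100 nM, compound 2 `O=C1CNC(=O)N1C[C@H]1CN(c2ccc(-n3cc(-c4ccccn4)cn3)c(F)c2)C(=O)O1` gives 1630000 nM, and compound 3 `O=C1O[C@@H](Cn2ccnc2)CN1c1ccc(-n2cc(-c3ccccn3)cn2)c(F)c1` gives 12300 nM, the lowest of the three. Both changes away from it in this assay were beyond the scatter: a 7.5-fold lower number from compound 1 to compound 3 (0.87 log units; beyond the scatter) and a 130-fold lower number from compound 2 to compound 3 (2.12 log units; beyond the scatter); the remaining step, an 18-fold higher number from compound 1 to compound 2 (1.25 log units; beyond the scatter), shows the two-carbonyl ring far ahead of the ester-bearing piperidine.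

Compound 4 `CCC(=O)NC[C@H]1CN(c2ccc(-n3cc(-c4ccccn4)cn3)c(F)c2)C(=O)O1` is the next unmeasured member. Its difference from compound 3 is propanoylamino in place of 1H-imidazol-1-yl on a saturated chain carbon bound to a saturated ring carbon; cut one bond further out it reads (1H-imidazol-1-yl)methyl to (propanoylamino)methyl. The entering group brings 1 hydrogen-bond donor and 1 hydrogen-bond acceptor and no ring, where the leaving group has 2 acceptors and an aromatic ring.

Both measured steps bearing on compound 3 ran upward when the imidazolyl left, so a rise beyond the scatter is expected for compound 4 as well, a 16-fold higher number from compound 3 to compound 4 (1.21 log units; beyond the scatter), though less than that seen for compound 2, because compound 2 gives 1630000 nM with a group that carries two carbonyls where the entering group carries one. Compound 4 is therefore estimated at 200000 nM, with a range from 50000 nM to 900000 nM.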

Compound 4, solubility: 147000 nM
Compound 4: the middle estimate sits 1.4-fold (0.13 log units) above what was measured; measured number inside the range.
By their numbers in this assay, from the lowest: compound 3; then compounds 1 and 4 (each within the scatter of the next); then compound 2.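

In this assay, going by these compounds alone, propanoylamino is the first group at this place, on a saturated chain carbon bound to a saturated ring carbon, that has no ring, and it stands clearly apart from the 1H-imidazol-1-yl of compound 3 (a 12-fold higher number from compound 3 to compound 4 (1.08 log units; beyond the scatter)). A ring in the group is therefore not needed for a number well clear of compound 3, and the open-chain amide cannot be told apart from the 4-((methoxycarbonyl)methyl)piperidin-1-yl group of compound 1 (a 1.6-fold higher number from compound 1 to compound 4 (0.20 log units; within the scatter)), yet it remains clearly separated from the 2,5-dioxoimidazolidin-1-yl group of compound 2 (an 11-fold lower number from compound 2 to compound 4 (1.04 log units; beyond the scatter)). Nothing in the available evidence accounts for this ordering.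

The compounds shown leave open whether the step from compound 3 to compound 4 goes with the amide hydrogen, the carbonyl or the loss of the aromatic ring, as all three differ together in this one change. A primary amine, a carboxylic acid or a longer acyl chain at the same place would give further points for separating these features.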